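Removing one methoxy from compound 3

A few compounds are considered here, and "the series" means these few. Any claim that something is new, unique, unknown or untested is made for them only; others in the source may bear on it.

Compound 3 (`COc1ccc2c(=O)cc(/C=C/[S+](C)[O-])oc2c1OC`) gives > 10000 nM in an ADME assay on WS1 cells (Homo sapiens) for inhibition, with a stated time of 48 h (on this read-out higher numbers stand for weaker inhibition and lower numbers for stronger inhibition), which is a limit of the assay and not a number. Compound 3 therefore stands at the limit of > 10000 nM in this assay, at which 2 of the 3 values shown sit. Compound 1 (`COc1cc2oc(/C=C/[S+](C)[O-])cc(=O)c2cc1O`) gives > 10000 nM, also a limit and not a number. Among the measured compounds shown here, compound 2 (`C[S+]([O-])/C=C/c1cc(=O)c2ccccc2o1`) is the only member with a measured number, at 9000 nM. For the measured compounds named here, no step between measured compounds that differ in one place is available, so the series offers no direct measure of what a single change does.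

Compound 4 (`COc1ccc2c(=O)cc(/C=C/[S+](C)[O-])oc2c1`) follows from compound 3 through one change, hydrogen in place of methoxy on an aromatic carbon. The new hydrogen sits ortho to a methoxy group, so one methoxy remains on the core. The expectation rests on compound 2, which carries no methoxy and gives 9000 nM. No shift beyond the usual scatter is expected in this assay, and no firm direction can be assigned, so the expected step is small: an at least 1.1-fold lower number from compound 3 to compound 4 (0.04 log units; that floor lies within the scatter). Compound 4 may well read as a limit too. The estimate for compound 4 is 9000 nM, with an expected range of 4000 nM to 16000 nM.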

Compound 4, half-maximal inhibitory concentration: 9000 nM
Compound 4: the middle estimate sits on the measured number at the digits printed; low and high end bracket the measured number.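

Working notes: the first direct one-place reading in this assay is no change at the digits printed from compound 2 to compound 4 (within the scatter), for methoxy in place of hydrogen on an aromatic carbon, so a single methoxy on the core is compatible with a number that stays within the scatter of the unsubstituted compound. At the carbon ortho to a methoxy group, hydrogen in place of methoxy reads as an at least 1.1-fold lower number from compound 3 to compound 4 (0.04 log units; that floor lies within the scatter), and the loss of the hydroxy reads as an at least 1.1-fold lower number from compound 1 to compound 4 (0.04 log units; that floor lies within the scatter); both steps start from a limit of the assay, and both floors lie within the scatter. Compound 1 and compound 3 each remain a limit and not a number, so the full size of these two steps stays unread: the limit of > 10000 nM in this assay, at which 2 of the 4 values shown sit.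

Whether any group on this aromatic carbon can move the number beyond the scatter remains open, as the compounds shown carry only hydrogen, methoxy or hydroxy on that ring; an amine or a fluorine there would be a wider test. The side chain on the shared core is the same in all four compounds, so the effect of a longer chain or a carboxylic acid at that place is also unknown.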